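This account rests on a few compounds, and the source may have more. Where it says the series, first, only, none or still open, it means among the compounds named here.

In a functional assay on LNCaP cells (Homo sapiens) for antiproliferative activity, read by propidium iodide staining, with a stated time of 96 h (a higher number here means a weaker inhibitor, a lower number a stronger inhibitor), compound 1 `CC(O)(CSc1cccc(S(F)(F)(F)(F)F)c1)C(=O)Nc1ccc(C#N)cc1C(F)(F)F` gives 17600 nM and compound 2 `CC(O)(CSc1ccc(S(F)(F)(F)(F)F)cc1)C(=O)Nc1ccc(S(F)(F)(F)(F)F)cc1` gives 18300 nM. These two values lie within the usual scatter of each other, so compound 2 cannot be ranked against compound 1. Compound 3 `CC(O)(CSc1ccc(OC(F)(F)F)cc1)C(=O)Nc1ccc(S(F)(F)(F)(F)F)cc1` is compound 2 with a single change on an aromatic carbon: a group of 5 heavy atoms (1 carbon, 1 oxygen, 3 fluorine; no ring) in place of a group of 6 heavy atoms (5 fluorine, 1 sulfur; no ring), on an aromatic carbon. Among the compounds with values here, no measured pair here isolates a single change, so the data offer no direct guide to its size. The expected move is a 1.1-fold lower number from compound 2 to compound 3 (0.06 log units; within the scatter), with no shift beyond the scatter in either direction. For compound 3 the estimated value is 16000 nM, within an expected range of 6500 nM to 38000 nM.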

Compound 3, half-maximal inhibitory concentration: 16100 nM
For compound 3 the middle estimate is 1.0-fold (0.00 log units) below the measured one, and the stated range covers the measured number.
By their numbers in this assay, from the lowest: compounds 3, 1 and 2 (each within the scatter of the next).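

In this assay, putting trifluoromethoxy in place of the sulfur group bearing five fluorines, on the aromatic carbon para to a large group, gives a 1.1-fold lower number from compound 2 to compound 3 (0.06 log units; within the scatter) and so lies within the scatter. Within the data shown here, this is the first pair here that differs in one place, and it shows that these two groups cannot be told apart at this position. Nothing available accounts for this result. The compounds shown leave open whether a different kind of group at this position, such as an amine or a carboxylic acid, would move the number beyond the scatter.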